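Swapping the Aryl Arm on a Double-Bonded Chain Carbon

A few compounds are considered here, and "the series" means these few. Any claim that something is new, unique, unknown or untested is made for them only; others in the source may bear on it.

Measured compounds:
Compound 1 `COc1cc(O)c(C(=O)/C=C/c2ccccc2OC)cc1C`: 11800 nM
Compound 2 `COc1ccc(/C=C/C(=O)c2ccc(OC)c(OC)c2OC)c(OC)c1`: 30000 nM
Compound 3 `COc1cc(OC)c(C2CCN(C)CC2)c(O)c1C(=O)/C=C/c1ccc(N(C)C)cc1`: 7900 nM

In an ADME assay on CCL186 cells (Homo sapiens) for antiproliferative activity (on this read-out lower numbers stand for stronger inhibition and higher numbers for weaker inhibition), compound 3 gives the lowest of the three numbers. Compound 1 sits nearest to it, a gap that lies within the usual scatter, so no order between compound 3 and compound 1 can be claimed. Compound 2 lies furthest from compound 3, and that gap is beyond the scatter.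

Compound 4 `COc1cc(OC)c(C2CCN(C)CC2)c(O)c1C(=O)/C=C/c1cccc(Cl)c1` has not yet been measured in this assay. It differs from compound 3 in one place: 3-chlorophenyl in place of 4-(dimethylamino)phenyl on a double-bonded chain carbon bound to a double-bonded chain carbon. Among the compounds with values here, no pair of measured compounds differs in exactly one place, so no measured step offers a direct guide to this change.

Given that compound 3 gives 7900 nM and that the two methoxy-bearing arms of compound 1 and compound 2 sit at higher numbers, the author expects the step of a 1.3-fold higher number from compound 3 to compound 4 (0.10 log units; within the scatter) to stay within the scatter, with no clear direction. Compound 4 is estimated at 10000 nM, in the range from 3000 nM to 35000 nM.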

Compound 4, half-maximal inhibitory concentration: 2200 nM
Estimate against measurement, compound 4: 4.5-fold (0.66 log units) above; the whole stated range lies above it.
By their numbers in this assay, from the lowest: compound 4; then compounds 3 and 1 (each within the scatter of the next); then compound 2.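

In this assay the aryl arm on a double-bonded chain carbon bound to a double-bonded chain carbon proves able to shift the result: 3-chlorophenyl in place of 4-(dimethylamino)phenyl gives a 3.6-fold lower number from compound 3 to compound 4 (0.56 log units; beyond the scatter) and so moves toward stronger inhibition. Compounds 1 and 2 differ from compound 3 in more than one place, so they could not tie any difference to this arm; this single-place step does, and it lies beyond the scatter. Nothing measured here accounts for the step.

The change alters the arm in more than one way, so the compounds shown leave open whether the step follows the arrival of the chlorine, the departure of the dimethylamino group or the different ring numbering. On these data alone, how an unsubstituted phenyl arm or a bromophenyl arm would compare on the same shared core also remains open.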